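This account rests on a few compounds, and the source may have more. Where it says the series, first, only, none or still open, it means among the compounds named here.

Compound 1 `O=C(Nc1ccc(Cl)c(-c2nnc3c(Cl)cccn23)c1)c1ccc(F)cc1Cl` is the reference point of this comparison. In a functional assay on A549 cells (Homo sapiens) for antiproliferative activity, read by MTT assay, with a stated time of 72 h (on this read-out higher numbers stand for weaker inhibition and lower numbers for stronger inhibition), compound 1 yields no number but only a limit, > 100000 nM, and that reading is the limit of > 100000 nM in this assay, at which 1 of the 3 values shown sits. Compound 2 `O=C(Nc1ccc(Cl)c(-c2nnc3c(Cl)cccn23)c1)c1ccc(Cl)cc1Cl` gives 61300 nM in this assay, and compound 3 `O=C(Nc1ccc(Cl)c(-c2nnc3c(Cl)cccn23)c1)c1c(F)cccc1Cl` gives 72300 nM. The measured steps that leave compound 1 are therefore both anchored at the limit: there is an at least 1.6-fold lower number from compound 1 to compound 2 (0.21 log units; that floor lies within the scatter) and an at least 1.3-fold lower number from compound 1 to compound 3 (0.14 log units; that floor lies within the scatter), while between the two numbered compounds there is a 1.2-fold higher number from compound 2 to compound 3 (0.07 log units; within the scatter). All three steps stay within the scatter, so changes to the ring on the carbonyl carbon have so far moved nothing that can be told apart from noise.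

Compound 4 `O=C(Nc1ccc(Cl)c(-c2nnc3c(Cl)cccn23)c1)c1cccnc1Cl` is not yet measured. The change from compound 1 is 2-chloropyridin-3-yl in place of 2-chloro-4-fluorophenyl on a carbonyl carbon. The two steps that bear on it, from compound 1 to compound 2 and from compound 1 to compound 3, were each at most a small lowering of the number, and on that basis no step beyond the scatter is expected in this assay. The expected step is an at least 1.1-fold lower number from compound 1 to compound 4 (0.04 log units; that floor lies within the scatter). Compound 4 is accordingly estimated at 90000 nM, with a range from 40000 nM to 250000 nM.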

Compound 4, half-maximal inhibitory concentration: 35800 nM
Compound 4: the middle estimate sits 2.5-fold (0.40 log units) above what was measured, outside the stated range (below it).
By their numbers in this assay, from the lowest: compounds 4, 2 and 3 (each within the scatter of the next, the first and the last beyond it). At a limit, above all of these: compound 1.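

In this assay, the 2-chloropyridin-3-yl group on the carbonyl carbon is the first replacement shown at this place to give a step beyond the scatter, and it does so from two starting points (an at least 2.7-fold lower number from compound 1 to compound 4 (0.44 log units; beyond the scatter)) and (a 2.0-fold lower number from compound 3 to compound 4 (0.31 log units; beyond the scatter)). Set against the 2,4-dichlorophenyl group, the same change stays within the scatter (a 1.7-fold lower number from compound 2 to compound 4 (0.23 log units; within the scatter)), so the 2-chloropyridin-3-yl group does not stand clear of every phenyl group shown. The step from compound 1 gives only a floor, since compound 1 carries a limit and not a number: the limit of > 100000 nM in this assay, at which 1 of the 4 values shown sits.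

The compounds shown leave open whether the step comes from the ring nitrogen itself or from the loss of the fluoro group, as the two go together in each replacement of a fluorinated phenyl group. They also leave open what a methoxy group or an amine on the 2-chloropyridin-3-yl group, or a pyridin-3-yl group without the chloro group, would do to the number at this place.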